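The compounds below may be only part of what the source reports. "The series", "measured", "known", "first", "only" and "open" are said of these compounds alone.

Compound 1 `CCOC(=O)c1oc2ccc(NS(=O)(=O)c3cccc(C)c3)cc2c1C` gives 29500 nM in a functional assay on MDA-MB-231 cells (Homo sapiens) for antiproliferative activity, read by MTT assay, with a stated time of 72 h; on this read-out higher numbers stand for weaker inhibition and lower numbers for stronger inhibition.
Compound 2 `CCOC(=O)c1oc2ccc(NS(=O)(=O)c3cccc(Cl)c3)cc2c1C` gives 57300 nM in this assay.
Compound 3 `CCOC(=O)c1oc2ccc(NS(=O)(=O)c3ccccc3Cl)cc2c1C` gives > 200000 nM in this assay, which is a limit of the assay and not a number.

Among the numbers shown, compound 2 holds the higher of the two; its nearest neighbour is compound 1, and the step of a 1.9-fold higher number from compound 1 to compound 2 (0.29 log units; within the scatter) lies within the scatter. Compound 4 `CCOC(=O)c1oc2ccc(NS(=O)(=O)c3cccc(C(F)(F)F)c3)cc2c1C` differs from compound 2 by trifluoromethyl in place of chloro on an aromatic carbon. The step most like this one is a 1.9-fold higher number from compound 1 to compound 2 (0.29 log units; within the scatter), a swap of one small group for another at the same place, which stayed within the scatter. The steps of an at least 6.7-fold higher number from compound 1 to compound 3 (0.83 log units; beyond the scatter) and an at least 3.4-fold higher number from compound 2 to compound 3 (0.54 log units; beyond the scatter) exchange the whole ring for 2-chlorophenyl and bear less directly. No step beyond the scatter is therefore expected in this assay, with the expected step of a 1.0-fold higher number from compound 2 to compound 4 (0.02 log units; within the scatter). Compound 4 is estimated at 60000 nM, between 25000 nM and 150000 nM.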

Compound 4, half-maximal inhibitory concentration: 30200 nM
Compound 4: middle estimate off by 2.0-fold (0.30 log units), on the high side; the measured number falls inside the stated range.
By their numbers in this assay, from the lowest: compounds 1, 4 and 2 (each within the scatter of the next). At a limit, above all of these: compound 3.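

On this aromatic carbon in this assay, the group can grow from one heavy atom to four without a change beyond the scatter: a 1.9-fold lower number from compound 2 to compound 4 (0.28 log units; within the scatter) and a 1.0-fold higher number from compound 1 to compound 4 (0.01 log units; within the scatter). Compound 1, compound 2 and compound 4 therefore cannot be ranked, whether methyl, chloro or trifluoromethyl sits at this place.

Nothing shown explains why these three groups give such close numbers. From the compounds shown here alone, whether an amine or a carboxylic acid at this place would keep the number in the same range remains open.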